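Swapping Methoxy for Methyl on the Ketone-Bearing Ring

This account rests on a few compounds, and the source may have more. Where it says the series, first, only, none or still open, it means among the compounds named here.

Measured so far:
compound 1 `COC(=O)c1c(Nc2ccccc2)sc(C(=O)c2ccc(OC)cc2)c1C` — 18%
compound 2 `COC(=O)c1c(Nc2ccc(OC)cc2)sc(C(=O)c2ccc(OC)cc2)c1C` — 5.9%
compound 3 `COC(=O)c1c(Nc2ccc(F)cc2)sc(C(=O)c2ccc(OC)cc2)c1C` — 14%

Of the compounds shown here, three sharing one core have been tested in a functional assay, with a stated time of 150 min, tested at 10 ug/mL; a lower number here means a weaker effect, a higher number a stronger effect of the compound at the concentration tested. Compound 1 gives the highest of the three numbers, 18%. Its step to compound 3, a number 4 percentage points lower from compound 1 to compound 3 (within the scatter), stays within the scatter, so the two cannot be ranked. Its step to compound 2, a number 12.1 percentage points lower from compound 1 to compound 2 (beyond the scatter), is modest but goes beyond the scatter, so compound 2 is genuinely weaker than compound 1 in this assay. The step from compound 2 to compound 3, a number 8.1 percentage points higher from compound 2 to compound 3 (within the scatter), is again within the scatter.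

Compound 4 `COC(=O)c1c(Nc2ccccc2)sc(C(=O)c2ccc(C)cc2)c1C` has not yet been measured. It differs from compound 1 in one place: methyl in place of methoxy on an aromatic carbon. For the measured compounds named here, every measured step concerns a group on another aromatic carbon, and none replaces a methoxy with a methyl, so no measured step bears directly on this change. Going by the values given here, the only step beyond the scatter, from compound 1 to compound 2, involved adding a methoxy elsewhere. Without a matching precedent, the expected step of no change at the digits printed from compound 1 to compound 4 (within the scatter) is taken as small, no larger than the scatter, in either direction.

Compound 4 is therefore estimated at 18%, with a range from 6% to 30%.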

Compound 4, a percentage reported as activity, at one concentration (the size of the read-out at that concentration, not a potency): 3.16%
Compound 4: middle estimate off by 14.8 percentage points, on the high side; the whole stated range lies above it.
By their numbers in this assay, from the lowest: compounds 4, 2, 3 and 1 (each within the scatter of the next, the first and the last beyond it).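

The earlier compounds shown here all carried the 4-methoxyphenyl group and differed only at an aromatic carbon elsewhere, so they showed nothing about this position. Exchanging 4-methoxyphenyl for 4-methylphenyl in this assay gives a number 14.8 percentage points lower from compound 1 to compound 4 (beyond the scatter), so a change at this position can move the number beyond the usual scatter, even though it removes only one heavy atom, the oxygen, and the one hydrogen-bond acceptor counted in the methoxy group. No measurement here explains why this exchange lowers the number.

The compounds shown cannot separate the loss of that oxygen from any other difference between the two groups, and a hydroxyl, an ethoxy or a plain hydrogen at the same place would help to test this. They also leave open whether the same exchange would lower the number to a similar extent in compounds 2 and 3, where the other aromatic ring carries a methoxy or a fluoro group.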